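This account rests on a few compounds, and the source may have more. Where it says the series, first, only, none or still open, it means among the compounds named here.

Series notes. All three measured compounds share one core and differ only in the aryl group on the carbon with a double bond to nitrogen. In an assay on isolated protein for inhibition of Maltase-glucoamylase (Homo sapiens), with a stated time of 15 min (a lower number here means a stronger inhibitor, a higher number a weaker inhibitor), compound 3 `O=C(N/N=C/c1ccc(O)c(O)c1)c1ccc(-c2nc3ccccc3s2)cc1` gives 15100 nM, the highest of the three numbers. Compound 2 `O=C(N/N=C/c1ccc(O)cc1)c1ccc(-c2nc3ccccc3s2)cc1` gives 11300 nM in this assay and sits nearest; the step of a 1.3-fold higher number from compound 2 to compound 3 (0.13 log units; within the scatter) is within the scatter. Compound 1 `COc1ccc(O)c(/C=N/NC(=O)c2ccc(-c3nc4ccccc4s3)cc2)c1` gives 6500 nM in this assay and is the furthest; the step of a 2.3-fold higher number from compound 1 to compound 3 (0.37 log units; beyond the scatter) is beyond the scatter, while the step of a 1.7-fold higher number from compound 1 to compound 2 (0.24 log units; within the scatter) is within it.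

Compound 4 `O=C(N/N=C/c1ccc(O)cc1O)c1ccc(-c2nc3ccccc3s2)cc1` is not yet measured. It differs from compound 3 by 2,4-dihydroxyphenyl in place of 3,4-dihydroxyphenyl on a carbon with a double bond to nitrogen. Among the compounds with values here, no measured step moves a hydroxy in this way, so none bears directly on it. The nearest reference points are the within-scatter change from compound 2 to compound 3 and the modest change from compound 1 to compound 3; the incoming group and the group of compound 1 both have names beginning with 2-hydroxy. Because the step of a 2.3-fold higher number from compound 1 to compound 3 (0.37 log units; beyond the scatter) is the only one beyond the scatter and goes upward to compound 3, a modest downward step a 1.9-fold lower number from compound 3 to compound 4 (0.28 log units; within the scatter) is expected for compound 4. Compound 4 is estimated at 8000 nM in this assay, with a range from 4000 nM to 16000 nM.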

Compound 4, half-maximal inhibitory concentration: 5580 nM
Estimate against measurement, compound 4: 1.4-fold (0.16 log units) above, within the range that was stated.
By their numbers in this assay, from the lowest: compounds 4, 1, 2 and 3 (each within the scatter of the next, the first and the last beyond it).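

In this assay, 2,4-dihydroxyphenyl in place of 3,4-dihydroxyphenyl on the carbon with a double bond to nitrogen gives a step beyond the scatter (a 2.7-fold lower number from compound 3 to compound 4 (0.43 log units; beyond the scatter)), with the same atoms and the same counts of donors and acceptors on both sides, so the arrangement of the two hydroxy groups on this ring matters here. The earlier hydroxy step on compound 2 stayed within the scatter, whereas this one goes beyond it (a 2.0-fold lower number from compound 2 to compound 4 (0.31 log units; beyond the scatter)), and among these compounds the outcome of adding a hydroxy therefore differs with where it stands. The 2,4-dihydroxyphenyl and 2-hydroxy-5-methoxyphenyl groups are not separated (a 1.2-fold lower number from compound 1 to compound 4 (0.07 log units; within the scatter)), although compound 1 is also not separated from compound 2. Nothing available gives a reason for these steps.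

Open, going by these compounds, is how a plain 2-hydroxyphenyl group would stand against 2,4-dihydroxyphenyl at this place. Also open, on these data alone, is whether an amine or a carboxylic acid in place of a hydroxy on this ring would keep a number close to that of compound 4.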